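This account rests on a few compounds, and the source may have more. Where it says the series, first, only, none or still open, it means among the compounds named here.

Measured in an ADME assay on microsomes from liver (Homo sapiens) for metabolic stability, read by LC-MS, with a stated time of 60 min; a lower number here means that less of the compound is left, a higher number that more of the compound is left:
- compound 1 `NC(=O)c1cnc2c(c1Cl)CCN2`: 57%
- compound 2 `C[C@@H]1Cc2cc(C(N)=O)cnc2N1`: 97%

Compound 2 holds the higher of these two numbers, and its gap to compound 1 lies beyond the usual scatter. The unmeasured compound 3 `NC(=O)c1cnc2c(c1)CCN2` has hydrogen in place of methyl on a saturated ring carbon. Among the compounds with values here, no measured pair shows this change alone, so any forecast is uncertain. A modest drop in this assay is expected, since compound 2 already stands at 97% and has little room to rise. The expected change is a number 12 percentage points lower from compound 2 to compound 3 (beyond the scatter). For compound 3 the estimate is 85%, with an expected range of 65% to 98%.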

Compound 3, percent of the compound remaining: 100%
Compound 3: middle estimate off by 15 percentage points, on the low side; measured number above the stated range.
By their numbers in this assay, from the lowest: compound 1; then compounds 2 and 3 (each within the scatter of the next).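

In this assay, hydrogen in place of methyl on a saturated ring carbon, next to the ring nitrogen, gives a number 3 percentage points higher from compound 2 to compound 3 (within the scatter), so this pair shows no need for the methyl. Hydrogen in place of chloro on an aromatic carbon gives a number 43 percentage points higher from compound 1 to compound 3 (beyond the scatter), which separates the chloro change from the methyl change and leaves the large step with the chloro. No measurement shown here explains either step.

Still open, going by these compounds, is whether an ethyl on that saturated ring carbon would stay within the scatter of compound 3. On these data alone, it is also open whether a fluoro or a methoxy on that aromatic carbon would give a step as large as the chloro.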